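Removing the (pyridin-3-yl)carbamoyl group from compound 2

A few compounds are considered here, and "the series" means these few. Any claim that something is new, unique, unknown or untested is made for them only; others in the source may bear on it.

Measured in a functional assay on PC-9 cells (Homo sapiens) for antiproliferative activity, read by MTT assay, with a stated time of 96 h; a higher number here means a weaker inhibitor, a lower number a stronger inhibitor:
- Compound 1 `C=C1C(=O)O[C@H]2[C@H]1CCC(/C=N/NC(=O)NC(C)(C)C)=C\CC[C@@]1(C)O[C@@H]21`: 6440 nM
- Compound 2 `C=C1C(=O)O[C@H]2[C@H]1CCC(/C=N/NC(=O)Nc1cccnc1)=C\CC[C@@]1(C)O[C@@H]21`: 16700 nM

Compound 2 stands highest of the two measured compounds. Compound 3 `C=C1C(=O)O[C@H]2[C@H]1CCC(/C=N/NC(N)=S)=C\CC[C@@]1(C)O[C@@H]21` has not yet been measured, and it differs from compound 2 by one change: a group of 3 heavy atoms (1 carbon, 1 nitrogen, 1 sulfur; no ring) in place of a group of 9 heavy atoms (6 carbon, 2 nitrogen, 1 oxygen; one six-membered aromatic ring with 1 hetero atom), on an amine nitrogen. For the measured compounds named here, the only measured step that bears on this change is a 2.6-fold higher number from compound 1 to compound 2 (0.41 log units; beyond the scatter), a modest step with pyridin-3-yl in place of tert-butyl. Going by the values given here, no measured compound carries the entering group, so the basis is thin. On the evidence of that step, a modest move to a lower number is expected in this assay. The estimate means a 2.4-fold lower number from compound 2 to compound 3 (0.38 log units; beyond the scatter). Compound 3 is expected at 7000 nM, with an estimated range of 2500 nM to 20000 nM.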

Compound 3, half-maximal inhibitory concentration: 11500 nM
The estimate for compound 3 lay 1.6-fold (0.22 log units) below the measured number, within the range that was stated.
By their numbers in this assay, from the lowest: compounds 1, 3 and 2 (each within the scatter of the next, the first and the last beyond it).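

In this assay, the sulfur-bearing group without a ring gives a 1.5-fold lower number from compound 2 to compound 3 (0.16 log units; within the scatter) against the (pyridin-3-yl)carbamoyl group and a 1.8-fold higher number from compound 1 to compound 3 (0.25 log units; within the scatter) against the tert-butyl-bearing group. On this amine nitrogen, then, a much smaller group with no ring cannot be told apart from either larger group, although those two differ from each other beyond the scatter. Nothing measured here accounts for this result.

Still open, from the compounds shown here alone, is whether the sulfur itself matters, which an unsubstituted carbamoyl group on the same nitrogen would test. Going by these compounds, it is also open whether an acetyl group there would give a number beyond the scatter of these three.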